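Swapping the pyrimidine for a plain phenyl ring

A few compounds are considered here, and "the series" means these few. Any claim that something is new, unique, unknown or untested is made for them only; others in the source may bear on it.

Of the compounds shown here, two with a shared core have been measured in an assay on isolated protein for inhibition of retinal dehydrogenase 2 (Homo sapiens); on this read-out higher numbers stand for weaker inhibition and lower numbers for stronger inhibition. Compound 1 `CC(Sc1nc2c(cnn2C)c(=O)n1-c1ccccc1)c1ccccn1` gives 63 nM. Among the compounds with values here, compound 2 `CC(Sc1nc2c(cnn2C)c(=O)n1-c1ccccc1)c1cncnc1` gives 380 nM, the highest number of the two; the only step to it, a 6.0-fold higher number from compound 1 to compound 2 (0.78 log units; beyond the scatter), shows how much the ring at that position matters. Compound 3 `CC(Sc1nc2c(cnn2C)c(=O)n1-c1ccccc1)c1ccccc1` is not yet measured; it differs from compound 2 by phenyl in place of pyrimidin-5-yl on a saturated chain carbon bound to a saturated chain carbon and a sulfur. Within the data shown here, no measured step covers the exchange of a nitrogen-containing ring for a carbon-only ring directly, so the step from compound 1 to compound 2 is the only guide, and it merely shows that this position is sensitive. A moderate move is therefore expected from compound 2 to compound 3, estimated as a 2.5-fold lower number from compound 2 to compound 3 (0.40 log units; beyond the scatter) in this assay. Compound 3 is expected to give an estimated 150 nM, within a range of 40 nM to 600 nM.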

Compound 3, half-maximal inhibitory concentration in the retinal dehydrogenase 2 assay: 110 nM
Beside the measured number, compound 3's estimate is 1.4-fold (0.13 log units) above it; measured number inside the range.
By their numbers in the retinal dehydrogenase 2 assay, from the lowest: compounds 1 and 3 (each within the scatter of the next); then compound 2.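

In the retinal dehydrogenase 2 assay, the phenyl ring takes back most of what the pyrimidin-5-yl ring gave up: a 3.5-fold lower number from compound 2 to compound 3 (0.54 log units; beyond the scatter). Against the pyridin-2-yl ring, phenyl shows a 1.7-fold higher number from compound 1 to compound 3 (0.24 log units; within the scatter), so this position does not need a nitrogen in its ring, and the pyrimidin-5-yl ring is the one that stands apart among these three compounds. The better inhibition comes at a price in a physicochemical assay for solubility, using the shake flask method, in phosphate buffer, with a stated time of 24 h, at pH 7.4 (a lower number here means a less soluble compound, a higher number a more soluble compound), where the same exchange costs much of the solubility: the measured solubility of compound 2, 264000 nM, and of compound 3, 8000 nM, a 33-fold lower number (1.52 log units; beyond the scatter). In the physicochemical assay compound 2 gives 264000 nM and compound 3 gives 8000 nM.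

Still open, on these data alone, is whether strong inhibition and high solubility can be combined at this position, for example with an amine on the same saturated chain carbon. The compounds shown also leave open how a methoxy group or a chlorine on the phenyl ring would shift either read-out.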